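Meta-halogen variation on the methylpyrrolidinylidene urea series

The source may report more compounds than this note shows. Statements on the series, on what has been measured and on what is new or still open speak of the compounds shown alone.

Measured so far in a functional assay on the whole organism with Rattus norvegicus as the target, with a stated time of 5 days; a higher number here means that more compound is needed for the effect, a lower number that less compound is needed:
Compound 1 `Cc1cccc(Cl)c1NC(=O)/N=C1\CCCN1C` gives only a limit, > 25 mg/kg.
Compound 2 `CN1CCC/C1=N\C(=O)Nc1cccc(Br)c1` gives 25 mg/kg.
Compound 3 `COc1cccc(OC)c1NC(=O)/N=C1\CCCN1C` gives only a limit, > 25 mg/kg.

Among the compounds with values here, compound 2 thus stands as the sole compound with a numerical result; the other two results are limits of this assay and not numbers. Within the data shown here, the series as a whole sits largely at the limit of > 25 mg/kg in this assay, at which 2 of the 3 values shown sit, so the range of the data is narrow and no step between measured compounds can be computed.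

Compound 4 `CN1CCC/C1=N\C(=O)Nc1cccc(F)c1` has not yet been run in this assay. It differs from compound 2 in one place: fluoro in place of bromo on an aromatic carbon. The substituent position is kept; only the halogen changes.

Among the measured compounds shown here, with no measured step to lean on, the expected step from compound 2 to compound 4, a 1.2-fold higher number from compound 2 to compound 4 (0.08 log units; within the scatter), is estimated to stay within the usual scatter, with the direction uncertain. For compound 4 the estimated minimum effective dose is 30 mg/kg, expected to lie between 12 mg/kg and 80 mg/kg. Given that compound 2 already sits at the edge where two of the other compounds gave only a limit, there is a fair chance that compound 4 too returns a limit rather than a number.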

Compound 4, minimum effective dose: 25 mg/kg
Beside the measured number, compound 4's estimate is 1.2-fold (0.08 log units) above it, within the range that was stated.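

Fluoro in place of bromo on the aromatic carbon gives, in this assay, no change at the digits printed from compound 2 to compound 4 (within the scatter). Within the data shown here, this is the first step that can be read, and it shows that at this place, meta to a large group, a numerical result holds with either halogen, so it does not depend on bromo alone. The read-out remains narrow, and no other step between the compounds shown can be read: the limit of > 25 mg/kg in this assay, at which 2 of the 4 values shown sit.

As far as these compounds go, what an amine or a carboxylic acid on this same aromatic carbon would give remains open. Among these compounds, also open is whether any group at this place can move the minimum effective dose beyond the scatter, as the only step available lies within it.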